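The compounds below may be only part of what the source reports. "The series", "measured", "known", "first", "only" and "open" are said of these compounds alone.

Measured in an ADME assay on liver (Rattus norvegicus) for activation, read by HPLC; a lower number here means that the compound disappears faster, a higher number that the compound lasts longer:
Compound 1, `COc1cc(NC(C)CCCNC(=O)Oc2ccc(Cl)cc2)c2ncccc2c1`, gives 11.8 h.
Compound 2, `COc1ccc(OC(=O)NCCCC(C)Nc2cc(OC)cc3cccnc23)cc1`, gives 10.3 h.
Compound 3, `CCOC(=O)NCCCC(C)Nc1cc(OC)cc2cccnc12`, gives 15.1 h.

Compound 2 has the lowest of the three numbers, but all three lie within the scatter of one another: a 1.1-fold lower number from compound 1 to compound 2 (0.06 log units; within the scatter) and a 1.5-fold higher number from compound 2 to compound 3 (0.17 log units; within the scatter). Compound 4, `COc1cc(NC(C)CCCNC(=O)Oc2ccccc2)c2ncccc2c1`, differs from compound 2 by hydrogen in place of methoxy on an aromatic carbon. The step that bears most on this change is the earlier exchange on the same aromatic carbon, a 1.1-fold lower number from compound 1 to compound 2 (0.06 log units; within the scatter), and the steps that exchange the whole group on the oxygen, a 1.3-fold higher number from compound 1 to compound 3 (0.11 log units; within the scatter) and a 1.5-fold higher number from compound 2 to compound 3 (0.17 log units; within the scatter), were also small. No step beyond the scatter is therefore expected in this assay, in either direction. Compound 4 is estimated at 11 h, with a range of 7 h to 17 h, which means an expected 1.1-fold higher number from compound 2 to compound 4 (0.03 log units; within the scatter).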

Compound 4, half-life: 9.5 h
Compound 4: the middle estimate sits 1.2-fold (0.06 log units) above what was measured; the range from low to high includes it.
By their numbers in this assay, from the lowest: compounds 4, 2, 1 and 3 (each within the scatter of the next).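

In this assay, hydrogen in place of methoxy on the aromatic carbon para to a large group gives a 1.1-fold lower number from compound 2 to compound 4 (0.04 log units; within the scatter), and hydrogen in place of chloro on that carbon gives a 1.2-fold lower number from compound 1 to compound 4 (0.09 log units; within the scatter), so the bare phenyl adds a third case at this position without a step beyond the scatter. Phenyl in place of ethyl on the oxygen next to the carbonyl group gives a 1.6-fold lower number from compound 3 to compound 4 (0.20 log units; within the scatter), which is also small. Nothing measured here accounts for these small steps.

From the compounds shown here alone, whether an amine or a carboxylic acid on this aromatic carbon would give a step beyond the scatter remains open. The same holds for a longer chain in place of ethyl on the oxygen.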